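The source may report more compounds than this note shows. Statements on the series, on what has been measured and on what is new or still open speak of the compounds shown alone.

Series notes. In a functional assay (muscle tissue) with Cavia porcellus as the target (on this read-out lower numbers stand for an effect already at smaller amounts and higher numbers for an effect only at larger amounts of compound), compound 1 `COC(=O)C1=C(C)N=C(C)/C(=C(\O)OC)C1c1ccccc1C#N` gives 15.9 nM. Compound 2 `COC(=O)C1=C(C)N=C(C)/C(=C(\O)OC)C1c1cc([N+](=O)[O-])ccc1Cl` gives 30.2 nM in this assay, and the gap between the two sits within the scatter of repeated measurements, so nothing separates them. Compound 3 `COC(=O)C1=C(C)N=C(C)/C(=C(\O)OC)C1c1ccccc1Br` is not yet measured in this assay. It differs from compound 1 by bromo in place of cyano on an aromatic carbon. Within the data shown here, no step between measured compounds bears on this change, so no direction is indicated beyond the scatter; the step of a 1.3-fold higher number from compound 1 to compound 3 (0.10 log units; within the scatter) is expected to stay within it. Compound 3 is accordingly estimated at 20 nM, with a range from 6 nM to 65 nM.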

Compound 3, half-maximal effective concentration: 7.59 nM
Beside the measured number, compound 3's estimate is 2.6-fold (0.42 log units) above it, within the range that was stated.
By their numbers in this assay, from the lowest: compound 3; then compounds 1 and 2 (each within the scatter of the next).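

In this assay, the 2-cyanophenyl to 2-bromophenyl change gives a 2.1-fold lower number from compound 1 to compound 3 (0.32 log units; beyond the scatter), a modest step and the only one in this series that shows this position, ortho to a large group, responding to a single change. The hydrogen-bond acceptor counted on cyano is absent from bromo, so the lower number here does not depend on having one at this place. Nothing available bears on why the number moves. As far as these compounds go, how a methyl group, an amine or a carboxylic acid would compare at this position remains open. From the compounds shown here alone, whether the step carries over to other substituents on the aromatic ring also remains open.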